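The source may report more compounds than this note shows. Statements on the series, on what has been measured and on what is new or still open speak of the compounds shown alone.

Measured so far in an ADME assay on microsomes from liver (Rattus norvegicus) for metabolic stability; on this read-out higher numbers stand for a longer-lived compound and lower numbers for a shorter-lived compound:
- Compound 1 `Nc1nc(NCCNc2ncc(-c3ncc[nH]3)c(-c3cc(F)ccc3F)n2)ccc1[N+](=O)[O-]`: > 0.5 h
- Compound 2 `Nc1nc(NCCNc2ncc(-c3ncc[nH]3)c(-c3cc(F)ccc3Cl)n2)ccc1[N+](=O)[O-]`: > 0.5 h
- Compound 3 `Nc1nc(NCCNc2ncc(-c3ncc[nH]3)c(-c3ccc(F)cc3C(F)(F)F)n2)ccc1[N+](=O)[O-]`: > 0.5 h

All three entries are limits and not numbers. As far as these compounds go, compound 3 therefore has only its limit of > 0.5 h, and its true half-life remains unknown. Compound 4 `Nc1nc(NCCNc2ncc(-c3ncc[nH]3)c(-c3cc(F)c(Cl)cc3Cl)n2)ccc1[N+](=O)[O-]` differs from compound 3 in one group: 2,4-dichloro-5-fluorophenyl in place of 4-fluoro-2-(trifluoromethyl)phenyl on an aromatic carbon. Three measured steps exchange this same group: a step that the two limits leave unreadable from compound 1 to compound 2, a step that the two limits leave unreadable from compound 1 to compound 3 and a step that the two limits leave unreadable from compound 2 to compound 3. None gives a size, because the limit of > 0.5 h in this assay, at which 3 of the 3 values shown sit, holds for compound 1, compound 2 and compound 3 alike. No change beyond the scatter is therefore expected in this assay, and no direction can be expected. The expected change is a step that the limit leaves unreadable from compound 3 to compound 4. For compound 4 the estimated half-life is 0.9 h, with an expected range from 0.5 h to 2.5 h.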

Compound 4, half-life: > 0.5 h
Compound 4: a limit, no number (the forecaster's own chance of this, stated with the estimate: 85%); the middle value lies beyond the limit too.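

Compound 4 adds no readable step to compound 1, compound 2 or compound 3 in this assay, because all four compounds share one limit: the limit of > 0.5 h in this assay, at which 4 of the 4 values shown sit. The compounds shown leave open the true half-life of each compound and whether the groups exchanged among them change it at all.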